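The source may hold more compounds than are shown below. What is called first, only, known or untested is meant among the compounds shown, and "the series" means these compounds.

In a physicochemical assay for solubility, read by chemiluminescence, measured as kinetic solubility (on this read-out lower numbers stand for lower solubility and higher numbers for higher solubility), compound 1 (`COc1cccc2c1c(NS(=O)(=O)c1ccc(Cl)s1)nn2Cc1cccc(CNC2COC2)c1`) gives 122 ug/mL. Compound 2 (`COc1cc(F)cc2c1c(NS(=O)(=O)c1ccc(Cl)s1)nn2Cc1cccc(CNC(C)=O)c1`), which carries an acetamidomethyl group, gives >= 161 ug/mL. That reading is a limit of the assay and not a number, and compound 2 therefore stands at the limit of >= 161 ug/mL in this assay, at which 1 of the 2 values shown sits.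

Compound 3 (`COc1cc(F)cc2c1c(NS(=O)(=O)c1ccc(Cl)s1)nn2Cc1cccc(CNC(=O)C(C)(C)O)c1`) is compound 2 with 1-hydroxy-1-methylethyl in place of methyl on a carbonyl carbon, so that the acetamidomethyl group becomes (((1-hydroxy-1-methylethyl)carbonyl)amino)methyl: 1-hydroxy-1-methylethyl in place of methyl on a carbonyl carbon. Within the data shown here, no measured pair of compounds shows this change in isolation, and the starting point is only a limit, so the direction of any step in this assay cannot be read from the data. Among the measured compounds shown here, with compound 1 at 122 ug/mL as the only full number available, a reading in the same region is expected. The expected step is an at least 1.1-fold lower number from compound 2 to compound 3 (0.06 log units; that floor lies within the scatter), which is not expected to go beyond the scatter. For compound 3 the estimated solubility is 140 ug/mL, with an expected range from 70 ug/mL to 210 ug/mL.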

Compound 3, solubility: >= 198 ug/mL
Compound 3 was reported as a limit; the forecaster's own chance of this, stated with the estimate: 40%; middle value at least 1.4-fold (0.15 log units) from the limit.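

No new step can be read from compound 2 to compound 3 in this assay; each reading is a limit of the assay and not a number. Compound 2 gives a limit: the limit of >= 161 ug/mL in this assay, at which 1 of the 3 values shown sits.

Compound 3 also gives a limit: the limit of >= 198 ug/mL in this assay, at which 1 of the 3 values shown sits.

The compounds shown leave open whether 1-hydroxy-1-methylethyl in place of methyl on a carbonyl carbon shifts the read-out at all, and in which direction.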